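Stomach dose series: thiourea and cyanoguanidine analogues

The compounds below may be only part of what the source reports. "The series", "measured", "known", "first", "only" and "open" are said of these compounds alone.

Compound 1 `O=c1ccc(-c2ccccc2)nn1CCCCNC(=S)Nc1cccc2ccccc12` in a functional assay on the whole organism (stomach) with Rattus norvegicus as the target; on this read-out higher numbers stand for an effect only at larger amounts of compound and lower numbers for an effect already at smaller amounts: > 100 mg/kg, a limit of the assay.
Compound 2 `C/N=C(/NC#N)NCCCCCn1nc(-c2ccccc2)c(C)cc1=O` in this assay: > 100 mg/kg, a limit of the assay.
Compound 3 `CC/N=C(/NC#N)NCCCCn1nc(-c2ccccc2)ccc1=O` in this assay: 92 mg/kg.

Compound 1 stands at the limit of > 100 mg/kg in this assay, at which 2 of the 3 values shown sit, so only a limit is known for it, not a number. Compound 4 `O=c1ccc(-c2ccccc2)nn1CCCCNC(=S)Nc1ccc(Cl)cc1` is not yet measured. It differs from compound 1 by 4-chlorophenyl in place of naphthalen-1-yl on an amide-type nitrogen. Going by the values given here, no measured step between compounds is available, so the size of this change in this assay is unknown; no shift beyond the scatter is expected in either direction. For compound 4 the estimate is 100 mg/kg, from 50 mg/kg to 300 mg/kg, which is expected to mean a number no higher from compound 1 to compound 4 (the limit leaves the size open).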

Compound 4, dose for half-maximal effect: > 100 mg/kg
Compound 4 was reported as a limit; the forecaster's own chance of this, stated with the estimate: 60%; the middle value sits exactly at the limit.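

In this assay, going by these compounds alone, compound 1 and compound 4 both give only limits of the assay, so no step between them can be read: the limit of > 100 mg/kg in this assay, at which 3 of the 4 values shown sit. From the compounds shown here alone, whether 4-chlorophenyl and naphthalen-1-yl on an amide-type nitrogen differ in effect stays open.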